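The compounds below may be only part of what the source reports. "The series", "measured", "known", "first", "only" and "open" are said of these compounds alone.

Measured in a functional assay on RS4-11 cells (Homo sapiens) for inhibition, read by CCK-8 assay, with a stated time of 48 h; on this read-out lower numbers stand for stronger inhibition and higher numbers for weaker inhibition:
- compound 1 `Nc1ccc(Oc2ccccc2-c2ccc(S(=O)(=O)NCCNC(=O)Nc3ccc(Cl)cc3)s2)cc1`: 13600 nM
- compound 2 `O=S(=O)(NCCNC(=S)Nc1cccc(Cl)c1)c1ccc(-c2ccccc2OCc2ccccc2)s1`: > 50000 nM, a limit of the assay and not a number
- compound 3 `Cc1cc(C)cc(NC(=O)NCCNS(=O)(=O)c2ccc(-c3ccccc3OCc3ccccc3)s2)c1`: > 50000 nM, a limit of the assay and not a number

Compound 3 has no numerical value, only a limit. It shares that position with compound 2, as the data show (the limit of > 50000 nM in this assay, at which 2 of the 3 values shown sit).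

Compound 4 `Cc1cc(C)cc(NC(=O)NCCNS(=O)(=O)c2ccc(-c3ccccc3Oc3ccc(N)cc3)s2)c1` keeps the rest of compound 3 and changes one group: 4-aminophenyl in place of benzyl on an oxygen on an aromatic ring.

Among the measured compounds shown here, no measured step covers this change. For the measured compounds named here, the one step available, a step that the two limits leave unreadable from compound 2 to compound 3, concerns another part of the molecule and gives no size to carry over. Going by the values given here, the only guide is compound 1, which carries the same 4-aminophenoxy group, although it also differs from compound 4 elsewhere. In this assay compound 1 gives 13600 nM, a true number, so a move toward stronger inhibition is expected, with its size uncertain.

The expected change is an at least 2.7-fold lower number from compound 3 to compound 4 (0.44 log units; beyond the scatter).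

Compound 4 is estimated at about 18000 nM, with an expected range of 6000 nM to 50000 nM.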

Compound 4, half-maximal inhibitory concentration: > 20000 nM
Compound 4: only a limit was reported (the forecaster's own chance of this, stated with the estimate: 25%); at least 1.1-fold (0.04 log units) between middle value and limit.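

In this assay compound 4 has only a limit and not a number, and it stands alone at that limit: the limit of > 20000 nM in this assay, at which 1 of the 4 values shown sits.

The steps between two limits cannot be read, so the swap of benzyl for 4-aminophenyl on the oxygen has no measurable size, even though the two compounds differ only there. Among the compounds shown here, the one readable comparison is an at least 1.4-fold higher number from compound 1 to compound 4 (0.16 log units; that floor lies within the scatter), with 3,5-dimethylphenyl in place of 4-chlorophenyl on an amide-type nitrogen. For the compounds shown here, this adds something the earlier compounds did not show: the 4-aminophenoxy group does not by itself give a numerical value, although the size of this step remains too uncertain to show that the change on the nitrogen matters.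

Going by these compounds, the true value of compound 4 remains open, and so does the effect of the 4-aminophenoxy group when 3,5-dimethylphenyl is kept constant. On these data alone, it is also open whether a 4-hydroxyphenyl or 4-methoxyphenyl group on the oxygen would bring the shared core to a numerical value in this assay.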